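The source may report more compounds than this note shows. Statements on the series, on what has been measured and on what is new or still open speak of the compounds shown alone.

Measured in a functional assay for inhibition, with Homo sapiens as the target; a lower number here means a stronger inhibitor, a higher number a weaker inhibitor:
- compound 1 `CC(C)=C1CS(=O)(=O)c2cc(C(=O)N=C(N)N)c(C)cc21`: 5030 nM
- compound 2 `Cc1cc2c(cc1C(=O)N=C(N)N)S(=O)(=O)CC2C`: 182 nM
- compound 3 `Cc1cc2c(cc1C(=O)N=C(N)N)S(=O)(=O)C(C)(C)C2=O`: 354 nM

Compound 2, at 182 nM, sits within the scatter of compound 3, at 354 nM. Compound 1, at 5030 nM, carries a higher number than compound 2, and that gap lies beyond the scatter.

The next compound is compound 4 `COC1CS(=O)(=O)c2cc(C(=O)N=C(N)N)c(C)cc21`, which differs from compound 2 by methoxy in place of methyl on a saturated ring carbon. Within the data shown here, no measured pair isolates this change, so the expectation is loose. Among the measured compounds shown here, with only three values, compound 1 at 5030 nM shows that the number can move far with changes at this part of the core, while compound 3 at 354 nM stays close to compound 2. A moderate shift towards a weaker inhibitor is expected, near the edge of the scatter. The estimated change is a 2.2-fold higher number from compound 2 to compound 4 (0.34 log units; beyond the scatter). For compound 4 the expected value in this assay is 400 nM, with an estimated range of 110 nM to 1500 nM.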

Compound 4, half-maximal inhibitory concentration: 208 nM
The estimate for compound 4 lay 1.9-fold (0.28 log units) above the measured number; low and high end bracket the measured number.
By their numbers in this assay, from the lowest: compounds 2, 4 and 3 (each within the scatter of the next); then compound 1.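

Methoxy in place of methyl on a saturated ring carbon, two ring bonds from the ring sulfur, gives a 1.1-fold higher number from compound 2 to compound 4 (0.06 log units; within the scatter) in this assay. Among these compounds, this is the first pair that isolates a single change, and it shows that this ring carbon can carry methoxy, with its extra oxygen and one hydrogen-bond acceptor, with no change in the number that stands out from the scatter. No measurement on hand explains this result.

The compounds shown leave open whether a hydroxyl, an amine, a carboxylic acid or a longer chain such as ethoxy at this ring carbon would also stay close to compound 2. A single pair also cannot say whether the same replacement would behave alike elsewhere on the shared core.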